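The compounds below may be only part of what the source reports. "The series", "measured", "known", "first", "only" and "open" are said of these compounds alone.

Measured compounds:
compound 1, `CC(C)(C)[C@H]1CC[C@H](N(Cc2ccc(C(=O)NCCC(=O)O)cc2)C(=O)Nc2ccc(C#N)cc2)CC1`: 1050 nM
compound 2, `CC(C)(C)[C@H]1CC[C@H](N(Cc2ccc(C(=O)NCCC(=O)O)cc2)C(=O)Nc2ccc(OCC3CC3)cc2C(F)(F)F)CC1`: 182 nM
compound 3, `COCCCNC(=O)c1ccc(CN(C(=O)Nc2ccc(OC(F)(F)F)cc2)C2CCC(C(C)(C)C)CC2)cc1`: > 10000 nM

All three were tested in an in vitro assay on BHK cells for inhibition of Glucagon receptor (Homo sapiens); a higher number here means a weaker inhibitor, a lower number a stronger inhibitor. Compound 1 gives 1050 nM and compound 2 gives 182 nM. For compound 3 the result is not a number but a limit, > 10000 nM; compound 3 therefore stands at the limit of > 10000 nM in this assay, at which 1 of the 3 values shown sits. Within the data shown here, no single step between measured compounds is available here, so the only orientation comes from these three values: the two compounds that carry an acid at the end of the side chain give numbers, while compound 3, with a methoxy-ended chain, does not.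

Compound 4, `CC(C)(C)C1CCC(N(Cc2ccc(C(=O)NCCC(N)=O)cc2)C(=O)Nc2ccc(OC(F)(F)F)cc2)CC1`, differs from compound 3 by carbamoyl in place of methoxymethyl on a saturated chain carbon, two bonds along the chain from an amide-type nitrogen. The resulting chain end is a primary amide rather than the acid of compound 1 and compound 2, so the expectation is a partial return toward measurable inhibition. The step from compound 3 to compound 4 is estimated as an at least 3.3-fold lower number from compound 3 to compound 4 (0.52 log units; beyond the scatter), in the direction of stronger inhibition. Compound 4 is thus expected to give about 3000 nM, within a range of 600 nM to 15000 nM, with a real chance that only a limit is reported again.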

Compound 4, half-maximal inhibitory concentration: > 10000 nM
Compound 4 was reported as a limit; the forecaster's own chance of this, stated with the estimate: 35%; at least 3.3-fold (0.52 log units) between middle value and limit.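

Among these compounds, compound 3 and compound 4 are both reported only as a limit and not as a number, so no step between them can be read: the limit of > 10000 nM in this assay, at which 2 of the 4 values shown sit. As far as these compounds go, what stays open is how far each compound lies beyond that limit, and whether carbamoyl in place of methoxymethyl changes inhibition at all.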